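Trifluoromethyl in Place of Methyl on the Lactone Core

The compounds below may be only part of what the source reports. "The series", "measured", "known", "first", "only" and "open" are said of these compounds alone.

Of the two compounds measured in a functional assay on MIA PaCa-2 cells (Homo sapiens) for cytotoxicity, read by MTT assay, with a stated time of 72 h, tested at 1 uM (a lower number here means a stronger effect, a higher number a weaker effect of the compound at the concentration tested), compound 2 `C=C1C(=O)O[C@H](c2ccc(C)cc2)[C@H]1c1ccccc1` stands as the stronger: compound 2 gives 26%, whereas compound 1 `C=C1C(=O)O[C@H](c2ccc(OC)cc2)[C@H]1c1ccccc1` gives 54%. Among the compounds with values here, the single measured step, a number 28 percentage points lower from compound 1 to compound 2 (beyond the scatter), lies beyond the scatter and is modest in size, so exchanging one small group for another at this position of the shared core has so far moved the read-out, but not dramatically.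

Compound 3 `C=C1C(=O)O[C@H](c2ccc(C(F)(F)F)cc2)[C@H]1c1ccccc1` has not yet been measured in this assay. It differs from compound 2 in one place: trifluoromethyl in place of methyl on an aromatic carbon. Within the data shown here, no measured step exchanges a methyl for a trifluoromethyl, and the one step that does exist, a number 28 percentage points lower from compound 1 to compound 2 (beyond the scatter), concerns a different pair of groups; its size is the only guide. A step of similar or smaller size is therefore expected, with no clear direction. Compound 3 is estimated to give about 30% in this assay, within a range from 12% to 55%, which means an expected step of a number 4 percentage points higher from compound 2 to compound 3 (within the scatter).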

Compound 3, a percentage reported as activity, at one concentration (the size of the read-out at that concentration, not a potency): 142%
Estimate against measurement, compound 3: 112 percentage points below; measured number above the stated range.
By their numbers in this assay, from the lowest: compound 2; then compound 1; then compound 3.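

In this assay the group on this aromatic carbon, para to a large group, matters far more than the first pair suggested: a number 116 percentage points higher from compound 2 to compound 3 (beyond the scatter) is a large step, whereas a number 28 percentage points lower from compound 1 to compound 2 (beyond the scatter) was only modest. The change to trifluoromethyl is also large when methoxy is the group replaced, with a number 88 percentage points higher from compound 1 to compound 3 (beyond the scatter) in the same direction, so compound 3 shows the weakest effect of the three compounds whichever of the two groups it is compared with. A single exchange on this carbon, with the rest of the shared core unchanged, can therefore move the read-out over a wide range, and nothing available here accounts for the sharp difference between methyl and trifluoromethyl.

The compounds shown leave open where other groups on this carbon, such as a chlorine atom, an amine or a carboxylic acid, would fall relative to methyl and trifluoromethyl. They also leave open whether trifluoromethyl in place of methyl would give a step of similar size and direction at another place on the shared core.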